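The source may hold more compounds than are shown below. What is called first, only, known or untested is meant among the compounds shown, and "the series" means these compounds.

Measured compounds in a physicochemical assay for lipophilicity, at pH 7.4; on this read-out higher numbers stand for higher lipophilicity and lower numbers for lower lipophilicity: compound 1 `CNC(=O)c1cc(C(=O)NC2CC2)cc2c1OC[C@H]2c1cccc2[nH]ccc12` gives 3.5; compound 2 `CNC(=O)c1cc(C(=O)N[C@H]2[C@@H]3COC[C@@H]32)cc2c1OC[C@H]2c1cccc(OC)c1` gives 3.2; compound 3 `CNC(=O)c1cc(C(=O)N[C@H]2[C@@H]3COC[C@@H]32)cc2c1OC[C@H]2c1cccc2[nH]ccc12` gives 3.1.

Compound 3 stands lowest of the three in this assay. Compound 2 lies within the scatter of it, while compound 1 stands apart, with a number 0.40 log units lower from compound 1 to compound 3 (beyond the scatter). Compound 4 `CNC(=O)c1cc(C(=O)N[C@H]2[C@@H]3COC[C@@H]32)cc2c1OC[C@H]2c1ccncc1` has not yet been measured; it differs from compound 3 in one place: pyridin-4-yl in place of 1H-indol-4-yl on a saturated ring carbon. Going by the values given here, the only measured step at that saturated ring carbon is a number 0.10 log units lower from compound 2 to compound 3 (within the scatter), which stayed within the scatter. The present change is larger by the counts shown, the entering group being the smaller one, and no measured pair carries a pyridin-4-yl group, so a downward step beyond the scatter is expected. Compound 4 is estimated at 2.3, between 1.8 and 2.8, an expected step of a number 0.80 log units lower from compound 3 to compound 4 (beyond the scatter).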

Compound 4, distribution coefficient: 1.3
Compound 4: the middle estimate sits 1.00 log units above what was measured; measured number below the stated range.
By their numbers in this assay, from the lowest: compound 4; then compounds 3, 2 and 1 (each within the scatter of the next, the first and the last beyond it).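

In this assay, the group on this saturated ring carbon turns out to matter greatly: 1H-indol-4-yl and 3-methoxyphenyl had stayed within the scatter of each other, whereas pyridin-4-yl gives a number 1.80 log units lower from compound 3 to compound 4 (beyond the scatter) and also a number 1.90 log units lower from compound 2 to compound 4 (beyond the scatter) in steps far larger than any seen before. The compounds shown offer no measurement that accounts for these steps.

Still open, from the compounds shown here alone, is how much of the drop goes with the ring nitrogen and how much with the smaller group, which an unsubstituted phenyl or a quinolinyl group on this carbon would help to separate. Going by these compounds, whether a pyridin-3-yl group would behave alike also remains unknown.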